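A few compounds are considered here, and "the series" means these few. Any claim that something is new, unique, unknown or untested is made for them only; others in the source may bear on it.

Three compounds have been measured so far in an ADME assay on MT4 cells (Homo sapiens) for cytotoxicity, read by MTT assay (a higher number here means that more compound is tolerated, a lower number that less compound is tolerated), and are given here:

compound 1 `Cc1ccc(CNC(=O)c2[nH]c3ccc(Cl)cc3c2S(=O)(=O)c2cc(C)cc(C)c2)cc1` gives 21200 nM as a number
compound 2 `Cc1cc(C)cc(S(=O)(=O)c2c(C(=O)NCc3cccc(F)c3)[nH]c3ccc(Cl)cc23)c1` gives > 53000 nM as a limit
compound 3 `Cc1cc(C)cc(S(=O)(=O)c2c(C(=O)NCc3ccccc3[N+](=O)[O-])[nH]c3ccc(Cl)cc23)c1` gives > 50200 nM as a limit

Compound 3 stands only at the limit > 50200 nM and has no exact number. The change to compound 4 `Cc1cc(C)cc(S(=O)(=O)c2c(C(=O)NCc3ccc(N)cc3)[nH]c3ccc(Cl)cc23)c1` puts 4-aminophenyl in place of 2-nitrophenyl on a saturated chain carbon bound to an amide-type nitrogen and leaves the shared core untouched.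

Three measured steps fall at this same place. The first is an at least 2.5-fold higher number from compound 1 to compound 2 (0.39 log units; beyond the scatter) and the second is an at least 2.3-fold higher number from compound 1 to compound 3 (0.37 log units; beyond the scatter) and both lie beyond the scatter. The third, a step that the two limits leave unreadable from compound 2 to compound 3 gives no size to work with.

The expectation leans on compound 1 at 21200 nM with its 4-methylphenyl, the group closest in name to 4-aminophenyl. On that ground a modest move to a lower number is expected in this assay and it may not clear the scatter. The estimated step is an at least 2.0-fold lower number from compound 3 to compound 4 (0.30 log units; that floor lies within the scatter) on this reading. For compound 4 the estimated value is 25000 nM with an expected range from 9000 nM to 60000 nM and a real chance of ending at only a limit.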

Compound 4, half-maximal cytotoxic concentration: 6370 nM
Compound 4: the middle estimate sits 3.9-fold (0.59 log units) above what was measured; measured number below the stated range.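

In this assay, this position proves able to fall well under the level of compound 1, and a swap confined to one substituent on the phenyl ring is enough: amino in place of methyl on an aromatic carbon gives a 3.3-fold lower number from compound 1 to compound 4 (0.52 log units; beyond the scatter), so two groups of the same size class of name, 4-methylphenyl and 4-aminophenyl, do not read alike here. Measured against the two halogen- and nitro-bearing benzyl amides, the fall is larger, with an at least 7.8-fold lower number from compound 3 to compound 4 (0.89 log units; beyond the scatter) and an at least 8.3-fold lower number from compound 2 to compound 4 (0.92 log units; beyond the scatter), and both of these sizes are floors rather than exact figures. The values of compound 2 and compound 3 are limits and not numbers, and nothing shown here gives a cause for the fall in compound 4.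

Going by these compounds, what stays open is whether the amino group itself carries this fall, which a 4-hydroxyphenyl or a 4-(dimethylamino)phenyl group in the same place would help to settle. On these data alone, it is also open whether an acetamide or a carboxylic acid on that phenyl ring would stay close to compound 4 or rise again toward the limits seen for compound 2 and compound 3.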